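Trimming a Chain and Watching Cytotoxicity

The compounds below may be only part of what the source reports. "The series", "measured", "known", "first", "only" and "open" are said of these compounds alone.

For the measured compounds named here, compound 2 `CCCCCCCCNc1cnc(C(=O)NCc2ccccc2)cn1` is the only compound here that returns a number rather than a limit: in an ADME assay on HeLa cells (Homo sapiens) for cytotoxicity, read by microscopy, with a stated time of 6 days (on this read-out lower numbers stand for higher toxicity in this test and higher numbers for lower toxicity in this test), compound 2 gives 100000 nM. Compound 1 `CCCCCCNc1cnc(C(=O)NCc2ccccc2)cn1` reaches only a limit of the test, > 100000 nM. Compound 3 `CCCCCCNc1cncc(C(=O)NCc2ccccc2)n1` likewise sits at a limit, > 100000 nM. Going by the values given here, the one measured step, a number no higher from compound 1 to compound 2 (the limit leaves the size open), cannot be sized because of the limit of > 100000 nM in this assay, at which 2 of the 3 values shown sit. Compound 4 `CCCCNc1cnc(C(=O)NCc2ccccc2)cn1` differs from compound 2 by hydrogen in place of butyl on a saturated chain carbon, four bonds along the chain from a nitrogen on an aromatic ring. Among the compounds with values here, with the only measured chain step of unreadable size, no change beyond the scatter is expected in this assay. Compound 4 is therefore expected to give about 100000 nM, between 50000 nM and 200000 nM. The expected step of no change at the digits printed from compound 2 to compound 4 (within the scatter) amounts to essentially no change, and a limit is quite possible.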

Compound 4, minimum cytotoxic concentration: > 100000 nM
Compound 4 ended at the assay's limit (the forecaster's own chance of this, stated with the estimate: 60%); the middle value lies on the limit itself.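

In this assay, hydrogen in place of butyl on this saturated chain carbon gives a number no lower from compound 2 to compound 4 (the limit leaves the size open). Compound 4 thus joins compound 1 at the limit of the test, so removing carbons from this chain brings no sign of added toxicity. Neither this step nor the one from compound 1 to compound 4 can be sized, because the values crowd at that limit: the limit of > 100000 nM in this assay, at which 3 of the 4 values shown sit.

The compounds shown leave open whether a longer chain would give a clearly lower number. They also leave open what an amine or a carboxylic acid on this chain would do.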